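Pyridin-3-yl to 2-methyl-1,3-thiazol-4-yl: cytotoxicity notes

The compounds below may be only part of what the source reports. "The series", "measured", "known", "first", "only" and "open" are said of these compounds alone.

Compound 1 (`COc1cccc(CCOc2ccc(-c3c(C)nc(C)c([C@H](OC(C)(C)C)C(=O)O)c3N3CCC(C)(C)CC3)cc2)c1`) and compound 2 (`Cc1nc(C)c([C@H](OC(C)(C)C)C(=O)O)c(N2CCC(C)(C)CC2)c1-c1ccc(OCCc2cccnc2)cc1`) share the same core and differ in one group on the side chain. In a toxicity assay on MT2 cells (Homo sapiens) for cytotoxicity, read by XTT assay, with a stated time of 4 days (on this read-out higher numbers stand for lower toxicity in this test and lower numbers for higher toxicity in this test), compound 1 gives >= 33500 nM as a limit and not a number. In this assay compound 2 gives >= 25000 nM as a limit and not a number. Going by the values given here, compound 2 therefore stands without a measured number, and so does the only other compound measured.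

Compound 3 (`Cc1nc(CCOc2ccc(-c3c(C)nc(C)c([C@H](OC(C)(C)C)C(=O)O)c3N3CCC(C)(C)CC3)cc2)cs1`) changes compound 2 on a saturated chain carbon, two bonds along the chain from an oxygen on an aromatic ring, with this difference: 2-methyl-1,3-thiazol-4-yl in place of pyridin-3-yl on a saturated chain carbon, two bonds along the chain from an oxygen on an aromatic ring and the core untouched.

Among the compounds with values here, the one measured step at this place is a step that the two limits leave unreadable from compound 1 to compound 2 and it offers no size to carry over. No step beyond the usual scatter is expected in this assay in either direction, though this is a weak expectation. The estimate amounts to a step that the limit leaves unreadable from compound 2 to compound 3 as the expected step. For compound 3 the estimated value is 30000 nM with an expected range of 10000 nM to 60000 nM and a report of only a limit is likely.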

Compound 3, half-maximal cytotoxic concentration: >= 25000 nM
Compound 3 gave a limit, no number (the forecaster's own chance of this, stated with the estimate: 70%); the middle value is on the limit's open side.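

In this assay compound 3 gives >= 25000 nM, a limit and not a number. Going by these compounds alone, with compound 1 and compound 2 also standing only as limits, no step among the three compounds can be read. Left open is whether 3-methoxyphenyl, pyridin-3-yl and 2-methyl-1,3-thiazol-4-yl differ at all in this assay, and at what concentration any of these compounds reaches the half-maximal cytotoxic effect.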